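Vinyl sulfone and sulfide series, growth inhibition in DU-145 cells

A few compounds are considered here, and "the series" means these few. Any claim that something is new, unique, unknown or untested is made for them only; others in the source may bear on it.

Measured so far:
compound 1 `Cc1ccc(CS(=O)(=O)/C(=C/c2c[nH]c3ccc(Br)cc23)C(=O)c2ccc(Cl)cc2)cc1`: 10000 nM
compound 2 `O=C(/C(=C\c1ccc(O)c([N+](=O)[O-])c1)Sc1ccccc1Br)c1ccc(Br)cc1`: 10000 nM
compound 3 `O=C(/C(=C\c1ccc(O)cc1)SCc1ccc(F)cc1)c1ccc(Cl)cc1`: 25000 nM

In a functional assay on DU-145 cells (Homo sapiens) for inhibition, read by trypan blue exclusion, with a stated time of 96 h (on this read-out higher numbers stand for weaker inhibition of growth and lower numbers for stronger inhibition of growth), compound 1 gives 10000 nM. Compound 2 gives 10000 nM in this assay, level with compound 1 at the digits shown, so the two cannot be ordered. Compound 3 gives 25000 nM, a higher number than compound 1 and beyond the scatter, so it is the weaker of that pair. All three sit at the weak end of the read-out.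

Compound 4 `Cc1ccc(CS(=O)(=O)/C(=C/c2sccc2C)C(=O)c2ccc(Cl)cc2)cc1` is not yet measured in this assay. It differs from compound 1 in one place: 3-methylthiophen-2-yl in place of 5-bromo-1H-indol-3-yl on a double-bonded chain carbon bound to a double-bonded chain carbon. Among the compounds with values here, no step between measured compounds bears on this change, so there is no direct precedent. Given that compound 1 gives 10000 nM, a step of modest size toward a higher number, or none beyond the scatter, is expected: a 1.5-fold higher number from compound 1 to compound 4 (0.18 log units; within the scatter). Compound 4 is estimated at 15000 nM, in the range 5000 nM to 50000 nM.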

Compound 4, concentration for 50% growth inhibition: 25000 nM
Estimate against measurement, compound 4: 1.7-fold (0.22 log units) below; the measured number falls inside the stated range.
By their numbers in this assay, from the lowest: compounds 1 and 2 (each within the scatter of the next); then compounds 3 and 4 (each within the scatter of the next).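

In this assay, within the data shown here, 3-methylthiophen-2-yl in place of 5-bromo-1H-indol-3-yl on a double-bonded chain carbon bound to a double-bonded chain carbon gives a 2.5-fold higher number from compound 1 to compound 4 (0.40 log units; beyond the scatter), the first comparison in this set that changes one place only. The number at this position therefore responds to the group carried there, although the step is modest. No measurement at hand accounts for the step.

Which part of the 5-bromo-1H-indol-3-yl group carries the step remains open. So does the effect of an amine or a carboxylic acid at this position.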